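The source may report more compounds than this note shows. Statements on the series, on what has been measured and on what is new or still open speak of the compounds shown alone.

Compound 1 `Nc1ccc2cccc(OCCCNC(=O)c3cccc(Cl)c3)c2n1`: 3 nM
Compound 2 `Nc1ccc2cccc(OCCCNC(=O)Nc3cccc(Cl)c3)c2n1`: 8 nM

Both compounds were tested in a functional assay on IMR-32 cells with melanin-concentrating hormone receptor 1 (Homo sapiens) as the target, read by fluorescence; on this read-out lower numbers stand for stronger inhibition and higher numbers for weaker inhibition. Compound 1 gives 3 nM, the lowest of the two numbers shown. For the measured compounds named here, compound 2 gives 8 nM, and a 2.7-fold higher number from compound 1 to compound 2 (0.43 log units; beyond the scatter), the single change being (3-chlorophenyl)amino in place of 3-chlorophenyl on the carbonyl carbon.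

Compound 3 `CCCNc1ccc2cccc(OCCCNC(=O)c3cccc(Cl)c3)c2n1` differs from compound 1 at a different place: propyl in place of hydrogen on a nitrogen on an aromatic ring, so that the amino group of the shared core becomes propylamino. Going by the values given here, the one measured step concerns the carbonyl end of the molecule, far from this nitrogen, and so does not bear on the change here. Among the compounds with values here, with no measured step touching the amino group, there is nothing to point to a shift in either direction, and the default expectation is a step that stays within the scatter, while allowing for the possibility that a propyl chain at this position changes the number by more than that. In this assay compound 3 is therefore expected to give about 5 nM, somewhere between 1.5 nM and 20 nM. The expected step is a 1.7-fold higher number from compound 1 to compound 3 (0.22 log units; within the scatter).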

Compound 3, half-maximal inhibitory concentration: 1120 nM
The estimate for compound 3 lay 220-fold (2.35 log units) below the measured number; the measured number lies above the stated range.
By their numbers in this assay, from the lowest: compound 1; then compound 2; then compound 3.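

The amino group of the shared core proves to be a highly sensitive place. In this assay, propyl on this nitrogen gives a 370-fold higher number from compound 1 to compound 3 (2.57 log units; beyond the scatter) and so moves the number much further than the change at the carbonyl end, which gave a 2.7-fold higher number from compound 1 to compound 2 (0.43 log units; beyond the scatter) in the opening pair. The entering group is small, with 3 heavy atoms, no ring and no net charge, so even a modest addition on this nitrogen can have a large effect in this compound, although nothing available explains why the number rises so steeply.

The compounds shown leave open whether a shorter group such as methyl or ethyl on this nitrogen would cost as much as propyl, and whether a ring-bearing group such as benzyl or a second substituent as in dimethylamino would do better or worse. They also leave open whether propyl on this nitrogen would have a similar effect when the carbonyl end carries the (3-chlorophenyl)amino group of compound 2.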